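Dimethylphenyl for Dichlorophenyl: Expected Cytotoxicity of Compound 4

The compounds below may be only part of what the source reports. "The series", "measured", "known", "first", "only" and "open" are said of these compounds alone.

Measured in a functional assay on HT-29 cells (Homo sapiens) for cytotoxicity, read by MTT assay, with a stated time of 2 days, tested at 10 uM; on this read-out lower numbers stand for less inhibition and higher numbers for more inhibition at the one concentration tested (going by the name of the read-out):
compound 1, `Cc1cccc(N2CCN(CCCNc3nc(NCc4ccco4)c4ccccc4n3)CC2)c1C`, gives 94%
compound 2, `Fc1ccc2nc(NCCCCN3CCN(c4cccc(Cl)c4Cl)CC3)nc(NCc3ccco3)c2c1`, gives 96.3%
compound 3, `Clc1cccc(N2CCN(CCCNc3nc(NCc4ccco4)c4ccccc4n3)CC2)c1Cl`, gives 94.1%

All three measured compounds share a core built around a furan-bearing side chain and a basic ring carrying an aryl group, and in this assay they all sit close together, with every gap between them inside the usual scatter of repeated measurements. For the measured compounds named here, the one change made between measured compounds is 2,3-dimethylphenyl in place of 2,3-dichlorophenyl on an amine nitrogen in a ring; that change gives a number 0.1 percentage points lower from compound 3 to compound 1 (within the scatter). Compound 2 and compound 3 differ in more than one place, and the difference between their two cores is not broken down here.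

Compound 4, `Cc1cccc(N2CCN(CCCCNc3nc(NCc4ccco4)c4cc(F)ccc4n3)CC2)c1C`, is not yet measured. It relates to compound 2 the way compound 1 relates to compound 3: the change is 2,3-dimethylphenyl in place of 2,3-dichlorophenyl on an amine nitrogen in a ring, and the place where it happens reads the same for both pairs, so this is the same change, now made on the core of compound 2 rather than on the core of compound 3. The step expected from compound 2 to compound 4 is a number 1.3 percentage points lower from compound 2 to compound 4 (within the scatter), close to no change, because a number 0.1 percentage points lower from compound 3 to compound 1 (within the scatter) was itself within the scatter. Compound 4 is therefore estimated at 95%, with a range from 87% to 100%.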

Compound 4, a percentage reported as inhibition, at one concentration (the size of the read-out at that concentration, not a potency): 96.1%
Compound 4: middle estimate off by 1.1 percentage points, on the low side, and the stated range covers the measured number.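

In this assay, putting 2,3-dimethylphenyl in place of 2,3-dichlorophenyl on the core of compound 2 gives a number 0.2 percentage points lower from compound 2 to compound 4 (within the scatter), so this swap leaves no readable mark on the number here. Set beside the earlier step, the same change reads alike on both cores, which means that in this small set it carries from one core to the other without a visible difference: the same change on two cores in this assay, a number 0.1 percentage points lower (within the scatter) from compound 3 to compound 1 and a number 0.2 percentage points lower (within the scatter) from compound 2 to compound 4, 0.1 percentage points apart, within the scatter of two such steps

This does not show that the two groups are equal in potency, since each step is read at one concentration only, and two cores are too few to support a rule for the whole series.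

The compounds shown leave open how other groups would read at this place on the ring nitrogen, such as plain phenyl, a pyridine ring or 2,3-dimethoxyphenyl, since only the dichlorophenyl and dimethylphenyl pair can be compared here. As far as these compounds go, it also remains open whether the same swap would stay as quiet on a core with a longer chain, or with chlorine or a methoxy group where compound 4 carries its fluorine.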